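The compounds below may be only part of what the source reports. "The series", "measured", "known", "first", "only" and "open" are said of these compounds alone.

Measured compounds in the series:

Compound 1, `CC1CC/C(=N\Nc2cccc(C(=O)O)c2)c2nccc(=O)n21`. In a functional assay on the whole organism for inhibition, with Rattus norvegicus as the target (a lower number here means that less compound is needed, a higher number that more compound is needed for the effect), compound 1 gives > 100 umol/kg, which is a limit of the assay and not a number.
Compound 2, `CC1CC/C(=N\Nc2ccccc2I)c2ncc(C(=O)O)c(=O)n21`. In this assay compound 2 gives > 1000 umol/kg, again a limit.
Compound 3, `CCOc1ccccc1N/N=C1\CCC(C)n2c1ncc(C(=O)O)c2=O`. In this assay compound 3 gives > 1000 umol/kg, also a limit.

Compound 2 therefore stands at a limit, not at a measured number, and the two further values in this assay are likewise limits: one value sits at the limit of > 100 umol/kg in this assay, at which 1 of the 3 values shown sits, and two values sit at the limit of > 1000 umol/kg in this assay, at which 2 of the 3 values shown sit. Among the measured compounds shown here, the only step between measured compounds that differ in one place, a step that the two limits leave unreadable from compound 2 to compound 3, is left unreadable by its two limits.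

Compound 4 is `Cc1cccc(N/N=C2\CCC(C)n3c2ncc(C(=O)O)c3=O)c1`. Relative to compound 2 the change is 3-methylphenyl in place of 2-iodophenyl on an amine nitrogen. For the measured compounds named here, no measured step bears on this change in a readable way; the exchange of iodo for ethoxy on the aromatic carbon gave no number on either side. Nothing in the series points to a step in this assay beyond the scatter in either direction, and the most that can be expected is that compound 4 also reaches only a limit. The expected step is a number no higher from compound 2 to compound 4 (the limit leaves the size open). For compound 4 the estimate in this assay is 1000 umol/kg, with a range from 150 umol/kg to 5000 umol/kg.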

Compound 4, dose for 50% inhibition: 72.5 umol/kg
Compound 4: the middle estimate sits 14-fold (1.14 log units) above what was measured, and the stated range ends above it.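

Among the compounds shown here, the exchange of 2-iodophenyl for 3-methylphenyl on the amine nitrogen gives an at least 13-fold lower number from compound 2 to compound 4 (1.13 log units; beyond the scatter) in this assay, and this is the first readable step. The earlier exchange of ethoxy for iodo cannot be read, so until now this position had shown no effect that could be sized; it now shows that a change in this group alone can move the read-out from a limit to a number. No measurement shown bears on why the number falls, and the two groups match in heavy atoms and in their counts of hydrogen-bond donors and acceptors.

The compounds shown leave open whether the step follows from the loss of iodo, from the arrival of methyl, or from the two together, as this single change carries both. Also open, from the compounds shown here alone, is whether an ethyl group or an amine on the same phenyl ring, in place of the methyl, would give a number in this assay or a limit.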